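Swapping the Group on the Saturated Ring Carbon

The source may report more compounds than this note shows. Statements on the series, on what has been measured and on what is new or still open speak of the compounds shown alone.

Compound 1 `Cc1nc(N2CCC(N3C(=O)CCC3=O)CC2)nc2ccc(NC(=O)/C=C/c3ccc(OC(F)(F)F)cc3)cc12` gives 40% in an ADME assay on microsomes from liver (Mus musculus) for metabolic stability, with a stated time of 30 min; on this read-out lower numbers stand for a less stable compound and higher numbers for a more stable compound.
Compound 2 `Cc1nc(N2CCC(N3CCOC3=O)CC2)nc2ccc(NC(=O)/C=C/c3ccc(OC(F)(F)F)cc3)cc12` gives 74% in this assay.

Going by the values given here, compound 2 stands highest of the two measured numbers; compound 1 is its only neighbour, and the step of a number 34 percentage points higher from compound 1 to compound 2 (beyond the scatter) lies beyond the scatter. The unmeasured compound 3 `COCC(=O)NC1CCN(c2nc(C)c3cc(NC(=O)/C=C/c4ccc(OC(F)(F)F)cc4)ccc3n2)CC1` differs from compound 2 in one place: ((methoxymethyl)carbonyl)amino in place of 2-oxo-1,3-oxazolidin-3-yl on a saturated ring carbon. Among the compounds with values here, the one measured step bears directly on this, since it also exchanged the group on the same saturated ring carbon and was large, so the read-out is clearly sensitive to what sits there. Whether a group with no ring pushes the number up or down cannot be read from compounds 1 and 2 alone. A moderate downward step is therefore expected, a number 14 percentage points lower from compound 2 to compound 3 (beyond the scatter), with a wide range around it. For compound 3 the estimate in this assay is 60%, between 35% and 85%.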

Compound 3, percent of the compound remaining: 57%
The estimate for compound 3 lay 3 percentage points above the measured number; low and high end bracket the measured number.
By their numbers in this assay, from the lowest: compound 1; then compound 3; then compound 2.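

In this assay, replacing 2-oxo-1,3-oxazolidin-3-yl with ((methoxymethyl)carbonyl)amino gives a number 17 percentage points lower from compound 2 to compound 3 (beyond the scatter) even though the heavy-atom count stays the same, so the read-out at this saturated ring carbon depends on more than the size of the group. Replacing 2,5-dioxopyrrolidin-1-yl with the same open group gives a number 17 percentage points higher from compound 1 to compound 3 (beyond the scatter) in the opposite direction, which places the group with no ring in the middle of the two five-membered ring groups and shows that having a ring does not by itself set the direction of the step. No measurement offered here explains this order.

The open group differs from 2-oxo-1,3-oxazolidin-3-yl both in lacking the ring and in carrying the amide hydrogen, and these compounds cannot separate the two. As far as these compounds go, how a primary amine, a carboxylic acid or a longer ether chain on this carbon would behave also remains open.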